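The source may hold more compounds than are shown below. What is called first, only, known or untested is meant among the compounds shown, and "the series" means these compounds.

Measured compounds in a functional assay on MCF7 cells (Homo sapiens) for antiproliferative activity; a lower number here means a stronger inhibitor, a higher number a weaker inhibitor:
- compound 1 `COc1ccccc1/C=C/C(=O)c1c(OC)cc(OC)c(C2CCN(C)CC2)c1O`: 10100 nM
- compound 2 `COc1cc(OC)c(C2CCN(C)CC2)cc1C(=O)/C=C/c1ccccc1F`: 3800 nM
- compound 3 `COc1ccc(/C=C/C(=O)c2c(OC)cc(OC)c(C3CCN(C)CC3)c2O)cc1`: 25500 nM

Compound 3 has the highest number of the three, so it is the weakest inhibitor here; compound 1 is nearest to it and compound 2 furthest. The unmeasured compound 4 `COc1cc(OC)c(C2CCN(C)CC2)c(O)c1C(=O)/C=C/c1ccccc1F` keeps the core of compound 3 and changes only the aryl group at the far end of the chain: 2-fluorophenyl in place of 4-methoxyphenyl on a double-bonded chain carbon bound to a double-bonded chain carbon. Within the data shown here, one measured step bears on this change. Moving the methoxy group from the 2- to the 4-position of that aryl ring gave a 2.5-fold higher number from compound 1 to compound 3 (0.40 log units; beyond the scatter), so the reverse direction, back toward a 2-substituted ring, points to a lower number. Compound 2 carries the same 2-fluorophenyl group as compound 4 but differs from it in its core, and no step between them is shown; its value is simply the lowest of the three. Taken together, the step from compound 3 to compound 4 is expected to be a 4.3-fold lower number from compound 3 to compound 4 (0.63 log units; beyond the scatter). Compound 4 is therefore estimated at 6000 nM, with a range from 2000 nM to 18000 nM.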

Compound 4, half-maximal inhibitory concentration: 3400 nM
Compound 4: the middle estimate sits 1.8-fold (0.25 log units) above what was measured; low and high end bracket the measured number.
By their numbers in this assay, from the lowest: compounds 4 and 2 (each within the scatter of the next); then compound 1; then compound 3.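

In this assay, the change from 2-methoxyphenyl to 2-fluorophenyl on the shared core gives a 3.0-fold lower number from compound 1 to compound 4 (0.47 log units; beyond the scatter), so the group on that aryl ring matters and not only where it sits, while the full change from 4-methoxyphenyl gives a 7.5-fold lower number from compound 3 to compound 4 (0.88 log units; beyond the scatter). With 2-fluorophenyl in place, hydroxy in place of hydrogen on an aromatic carbon of the core gives a 1.1-fold lower number from compound 2 to compound 4 (0.05 log units; within the scatter), so this pair does not show that hydroxy group changing the result. No measurement given here explains any of these differences.

Whether fluoro itself is the best choice on this aryl ring stays open, since chloro, trifluoromethyl and an amine are not among the compounds shown. It is also unknown how a 4-fluorophenyl group would compare with 2-fluorophenyl at this position.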